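Ring substituent on the core nitrogen: compound 4

The compounds below may be only part of what the source reports. "The series", "measured", "known", "first", "only" and "open" are said of these compounds alone.

Measured so far in an assay on HEK-293T cells for antagonist activity at vitamin D3 receptor (Homo sapiens), read by a luciferase reporter, with a stated time of 24 h; a higher number here means a weaker inhibitor, a lower number a stronger inhibitor:
compound 1 `CC(C)c1onc(-c2c(Cl)cccc2Cl)c1COc1ccc(-c2nc3ccc(C(=O)O)cc3n2C)cc1` gives 7150 nM
compound 2 `CCC(CC)n1c(-c2ccc(OCc3c(-c4c(Cl)cccc4Cl)noc3C(C)C)cc2F)nc2ccc(C(=O)O)cc21` gives > 10000 nM, which is a limit of the assay and not a number
compound 3 `CC(C)c1onc(-c2c(Cl)cccc2Cl)c1COc1ccc(-c2nc3ccc(C(=O)O)cc3n2CC(C)(C)C)cc1` gives 861 nM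

Compound 3 has the lowest of the two numbers shown in this assay; the nearest number is that of compound 1, and the step of an 8.3-fold lower number from compound 1 to compound 3 (0.92 log units; beyond the scatter) lies beyond the scatter. The value of compound 2 is a limit only the limit of > 10000 nM in this assay, at which 1 of the 3 values shown sits, and gives no number for a step, and compound 2 also differs from compound 3 in more than one place, so it does not bear directly on the change considered here.

Compound 4 `CC(C)c1onc(-c2c(Cl)cccc2Cl)c1COc1ccc(-c2nc3ccc(C(=O)O)cc3n2CC2CC2)cc1` is compound 3 with one change: cyclopropyl in place of tert-butyl on a saturated chain carbon bound to an aromatic nitrogen. Within the data shown here, the only measured step that touches this position is the one from hydrogen to tert-butyl, which lowered the number by a modest amount. Cyclopropyl sits between hydrogen and tert-butyl in the count of heavy atoms, so a number between those of compound 1 and compound 3 is expected, closer to compound 3, that is a small step upward, a 2.3-fold higher number from compound 3 to compound 4 (0.37 log units; beyond the scatter). For compound 4 the estimate in this assay is therefore 2000 nM, with a range from 700 nM to 6000 nM.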

Compound 4, half-maximal inhibitory concentration: 2650 nM
For compound 4 the middle estimate is 1.3-fold (0.12 log units) below the measured one; the range from low to high includes it.
By their numbers in this assay, from the lowest: compound 3; then compound 4; then compound 1. At a limit, above all of these: compound 2.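

The position on a saturated chain carbon bound to an aromatic nitrogen now has three readings in this assay and the lowering seen with tert-butyl is no longer the only one: cyclopropyl runs the same way, with a 2.7-fold lower number from compound 1 to compound 4 (0.43 log units; beyond the scatter) as the step from hydrogen. Cyclopropyl does not match tert-butyl, however, and a 3.1-fold higher number from compound 3 to compound 4 (0.49 log units; beyond the scatter) gives back part of that lowering, so the two groups are not interchangeable at this position and the three compounds fall in the order of the heavy atoms counted for hydrogen, cyclopropyl and tert-butyl, with none of the three against it. The values shown give no cause for this order.

Heavy-atom count and the ring change together from compound 3 to compound 4, so these compounds cannot say which of the two goes with the higher number. An open chain such as isobutyl, a larger ring such as cyclobutyl, or a chain ending in an amine or a carboxylic acid would test how far the order holds.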